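Swapping the Amine Linker for Sulfur

A few compounds are considered here, and "the series" means these few. Any claim that something is new, unique, unknown or untested is made for them only; others in the source may bear on it.

Going by the values given here, compound 2 `Nc1cc(N)c2nc(-c3ccccc3)c(NCc3ccc(F)cc3)nc2c1` is the lower of the two numbers measured so far in a functional assay on SF-539 cells (Homo sapiens) for inhibition, read by sulforhodamine B assay, with a stated time of 48 h (a higher number here means a weaker inhibitor of growth, a lower number a stronger inhibitor of growth), where compound 2 gives 3550 nM. Among the compounds with values here, compound 1 `COc1ccc(CNc2nc3cc(N)cc(N)c3nc2-c2ccccc2)cc1OC` gives 45700 nM, and the only measured step, a 13-fold lower number from compound 1 to compound 2 (1.11 log units; beyond the scatter), changed just the aryl group on the saturated chain carbon. Compound 3 `Nc1cc(N)c2nc(-c3ccccc3)c(Sc3ccc(F)cc3)nc2c1` differs from compound 2 in another way: (4-fluorophenyl)sulfanyl in place of (4-fluorobenzyl)amino on an aromatic carbon. Within the data shown here, no measured step touches the link between the shared core and the fluorinated ring, so the large step seen between compound 1 and compound 2 bears on this change only loosely, showing that this side of the molecule can move the number a great deal. With no direct guide, the expected step of a 1.1-fold higher number from compound 2 to compound 3 (0.05 log units; within the scatter) is none beyond the scatter, with wide uncertainty either way. Compound 3 is therefore estimated at 4000 nM, in a range from 1000 nM to 20000 nM.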

Compound 3, concentration for total growth inhibition: 39800 nM
Compound 3: middle estimate off by 10-fold (1.00 log units), on the low side, and the stated range ends below it.
By their numbers in this assay, from the lowest: compound 2; then compounds 3 and 1 (each within the scatter of the next).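

In this assay, the link between the shared core and the fluorinated ring proves to matter too, not just the aryl group at its end: putting (4-fluorophenyl)sulfanyl in place of (4-fluorobenzyl)amino on this aromatic carbon gives an 11-fold higher number from compound 2 to compound 3 (1.05 log units; beyond the scatter). Going by these compounds alone, this one swap alters several things at once: sulfur takes the place of nitrogen, the saturated chain carbon is gone, and the hydrogen-bond donor of the leaving group has no counterpart in the entering one. No measurement here explains the weaker growth inhibition.

Which of these alterations carries the loss stays open. A (4-fluorobenzyl)sulfanyl group, which keeps the chain carbon with sulfur, and a (4-fluorophenyl)amino group, which keeps the nitrogen without that carbon, would pull the two apart.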